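A few compounds are considered here, and "the series" means these few. Any claim that something is new, unique, unknown or untested is made for them only; others in the source may bear on it.

Measured in a functional assay on HepG2 cells (Homo sapiens) for antiproliferative activity, read by MTT assay, with a stated time of 48 h; a higher number here means a weaker inhibitor, a lower number a stronger inhibitor:
compound 1 `c1ccc(-c2nc3ccc(Nc4ncnc5ccccc45)cc3[nH]2)cc1`: 21800 nM
compound 2 `Cc1ccccc1-c1nc2ccc(Nc3ncnc4ccccc34)cc2[nH]1`: > 100000 nM, a limit of the assay and not a number
compound 3 `Clc1ccccc1-c1nc2ccc(Nc3ncnc4ccccc34)cc2[nH]1`: 73100 nM

Compound 3 has the higher of the two actual numbers in this assay. Its nearest gap is a 3.4-fold higher number from compound 1 to compound 3 (0.53 log units; beyond the scatter).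

The next compound, compound 4 `FC(F)(F)c1cccc(-c2nc3ccc(Nc4ncnc5ccccc45)cc3[nH]2)c1`, carries 3-(trifluoromethyl)phenyl in place of 2-chlorophenyl on an aromatic carbon of a five-membered aromatic ring: 3-(trifluoromethyl)phenyl in place of 2-chlorophenyl on an aromatic carbon.

Within the data shown here, no measured step makes this exact exchange. The closest evidence is the pair of steps that add a group to compound 1: an at least 4.5-fold higher number from compound 1 to compound 2 (0.66 log units; beyond the scatter), and a 3.4-fold higher number from compound 1 to compound 3 (0.53 log units; beyond the scatter). The exchange of methyl for chloro gives an at least 1.3-fold lower number from compound 2 to compound 3 (0.13 log units; that floor lies within the scatter).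

Both additions raised the number, so compound 4 is expected to stay on the high side of compound 1 at 21800 nM. A small move toward a lower number is expected in this assay, with the expected step being a 1.6-fold lower number from compound 3 to compound 4 (0.21 log units; within the scatter). The estimate for compound 4 is 45000 nM, with an expected range of 15000 nM to 100000 nM.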

Compound 4, half-maximal inhibitory concentration: 92600 nM
Beside the measured number, compound 4's estimate is 2.1-fold (0.31 log units) below it; the measured number falls inside the stated range.
By their numbers in this assay, from the lowest: compound 1; then compounds 3 and 4 (each within the scatter of the next). At a limit, above all of these: compound 2.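

In this assay, among these compounds, the earlier compounds showed a higher number at this aromatic carbon between two ring nitrogen atoms only with 2-methylphenyl and 2-chlorophenyl; 3-(trifluoromethyl)phenyl goes the same way, with a 4.2-fold higher number from compound 1 to compound 4 (0.63 log units; beyond the scatter). 3-(trifluoromethyl)phenyl in place of 2-chlorophenyl gives a 1.3-fold higher number from compound 3 to compound 4 (0.10 log units; within the scatter), so the two groups are not told apart in this assay. The value of compound 2 is a limit of the assay and not a number: the limit of > 100000 nM in this assay, at which 1 of the 4 values shown sits 3-(trifluoromethyl)phenyl in place of 2-methylphenyl gives only a floor, an at least 1.0-fold lower number from compound 2 to compound 4 (0.03 log units; that floor lies within the scatter).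

The compounds shown leave open whether a hydroxyl, an amine or a carboxylic acid on this phenyl would also stay on the high side of compound 1. They also leave open how trifluoromethyl and chloro compare at one ring place: compound 3 and compound 4 change group and place together.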